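Chloro on the Aromatic Ring of Compound 1

The source may report more compounds than this note shows. Statements on the series, on what has been measured and on what is new or still open speak of the compounds shown alone.

Among the compounds with values here, compound 1, `CN(C)C/C=C(/c1ccccc1)c1cccnc1`, is the only member of this small set for which a number rather than a limit is known: in an in vivo functional assay on the whole organism (brain) for inhibition of Norepinephrine transporter (Rattus norvegicus) (a higher number here means that more compound is needed for the effect, a lower number that less compound is needed), compound 1 gives 107 umol/kg. Compound 2, `Cc1ccc(/C(=C/CN(C)C)c2cccnc2)cc1`, carries a methyl in place of hydrogen on an aromatic carbon. In this assay compound 2 reaches only a limit, > 117 umol/kg. Compound 3, `COc1ccc(/C(=C/CN(C)C)c2cccnc2)cc1`, carries a methoxy at the same kind of position. For compound 3 this assay likewise yields a limit, > 112 umol/kg. The step of an at least 1.0-fold higher number from compound 1 to compound 2 (0.03 log units; that floor lies within the scatter) and the step of an at least 1.0-fold higher number from compound 1 to compound 3 (0.01 log units; that floor lies within the scatter) therefore set floors only, and the step that the two limits leave unreadable from compound 2 to compound 3 cannot be read.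

Compound 4, `CN(C)C/C=C(\c1cccnc1)c1cccc(Cl)c1`, differs from compound 1 by chloro in place of hydrogen on an aromatic carbon, the group sitting meta to a large group. Both substituents already tried on the aromatic ring, in compound 2 and compound 3, left this assay at a limit with floors within the scatter, so no step beyond the scatter is expected for compound 4 in this assay, with a tilt toward the higher side; the estimated step is a 1.2-fold higher number from compound 1 to compound 4 (0.08 log units; within the scatter). Compound 4 is thus expected at 130 umol/kg, between 55 umol/kg and 320 umol/kg.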

Compound 4, dose for half-maximal effect: > 110 umol/kg
Compound 4: no number, only a limit (the forecaster's own chance of this, stated with the estimate: 50%); the middle value is on the limit's open side.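

Compound 4 gives a limit of the assay rather than a number: the limit of > 110 umol/kg in this assay, at which 1 of the 4 values shown sits. Chloro in place of hydrogen, meta to a large group, therefore sets only a floor, an at least 1.0-fold higher number from compound 1 to compound 4 (0.01 log units; that floor lies within the scatter), and the true size of this step cannot be read. Together with compound 2 and compound 3, chloro is the third aromatic substituent on the core of compound 1 to yield no number in this assay, which leaves compound 1 as the only compound here with one.

The compounds shown leave open whether any group on this aromatic ring gives a number rather than a limit in this assay, for instance fluoro, hydroxy or an amine. They also leave open whether chloro would do so at another place on the ring, and whether the step from hydrogen to chloro is larger than its floor.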